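A Methoxy Removed From Compound 1

This account rests on a few compounds, and the source may have more. Where it says the series, first, only, none or still open, it means among the compounds named here.

Among the measured compounds shown here, compound 1 `COc1ccc(/C(=C\c2c[nH]c3ccc(OCc4ccccc4)cc23)C(=O)O)cc1` gives 38500 nM in a functional assay on KB cells (Homo sapiens) for cytotoxicity, read by MTT assay, with a stated time of 72 h (on this read-out higher numbers stand for weaker inhibition and lower numbers for stronger inhibition), the only number among the values shown. Its acetylated counterpart, compound 2 `COc1ccc(/C(=C\c2cn(C(C)=O)c3ccc(OCc4ccccc4)cc23)C(=O)O)cc1`, sits at > 100000 nM in this assay, which is a limit of the assay and not a number. The step of an at least 2.5-fold higher number from compound 1 to compound 2 (0.41 log units; beyond the scatter) concerns the aromatic nitrogen, not the aryl ring. Compound 3 `O=C(O)/C(=C/c1c[nH]c2ccc(OCc3ccccc3)cc12)c1ccccc1` differs from compound 1 by hydrogen in place of methoxy on an aromatic carbon. For the measured compounds named here, no measured step touches this position, so a step within the scatter is expected, a 1.3-fold higher number from compound 1 to compound 3 (0.11 log units; within the scatter). Compound 3 is estimated at 50000 nM, between 20000 nM and 120000 nM.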

Compound 3, half-maximal inhibitory concentration: 55500 nM
For compound 3 the middle estimate is 1.1-fold (0.05 log units) below the measured one, and the stated range covers the measured number.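

On the aryl ring, in this assay, going from 4-methoxyphenyl to phenyl gives a 1.4-fold higher number from compound 1 to compound 3 (0.16 log units; within the scatter). The methoxy group is thus the first place shown where a step stays within the scatter, unlike the acetyl step on the aromatic nitrogen, and the value of compound 1 offers no sign that this methoxy group matters here. Compound 2 stands at a limit of the assay and not at a number: the limit of > 100000 nM in this assay, at which 1 of the 3 values shown sits.

As far as these compounds go, it remains open whether an amine, a hydroxyl or a longer chain such as ethoxy on this carbon would give a step beyond the scatter. The same holds for an amide in place of the carboxylic acid.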